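Bromo for methoxy on the triazole aryl of a terpenoid ester

The source may hold more compounds than are shown below. What is called first, only, known or untested is meant among the compounds shown, and "the series" means these compounds.

Measured compounds:
compound 1, `COc1ccccc1-n1cc(COC(=O)/C(C)=C/CC/C(C)=C/CC/C(C)=C/CC[C@@H]2[C@@]3(C)CCC(=O)C(C)(C)[C@H]3CC[C@@]2(C)O)nn1`: > 150000 nM
compound 2, `C/C(=C\CC/C(C)=C/CC[C@@H]1[C@@]2(C)CCC(=O)C(C)(C)[C@H]2CC[C@@]1(C)O)CC/C=C(\C)C(=O)OCc1cn(-c2ccccc2Br)nn1`: > 150000 nM
compound 3, `COc1ccc(-n2cc(COC(=O)/C(C)=C/CC/C(C)=C/CC/C(C)=C/CC[C@@H]3[C@@]4(C)CCC(=O)C(C)(C)[C@H]4CC[C@@]3(C)O)nn2)cc1`: 135000 nM

Three esters of a shared terpenoid core were tested in a functional assay on DU-145 cells (Homo sapiens) for antiproliferative activity, read by MTT assay, with a stated time of 48 h; on this read-out lower numbers stand for stronger inhibition and higher numbers for weaker inhibition. Compound 1 reached only a limit of the assay there, namely > 150000 nM. Compound 2 likewise gave only a limit, > 150000 nM. Among the compounds with values here, compound 3 is the one member with a number: in this assay compound 3 gives 135000 nM. That number lies close to the point at which the other two values sit, (the limit of > 150000 nM in this assay, at which 2 of the 3 values shown sit).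

Compound 1 and compound 2 differ by bromo in place of methoxy on an aromatic carbon, and the step that the two limits leave unreadable from compound 1 to compound 2 cannot be sized. The cores of compound 1 and compound 3 differ by 4-methoxyphenyl in place of 2-methoxyphenyl on an aromatic nitrogen, with the step of an at least 1.1-fold lower number from compound 1 to compound 3 (0.04 log units; that floor lies within the scatter); the pair compound 2 and compound 3 shows an at least 1.1-fold lower number from compound 2 to compound 3 (0.04 log units; that floor lies within the scatter).

Compound 4, `C/C(=C\CC/C(C)=C/CC[C@@H]1[C@@]2(C)CCC(=O)C(C)(C)[C@H]2CC[C@@]1(C)O)CC/C=C(\C)C(=O)OCc1cn(-c2ccc(Br)cc2)nn1`, is not yet measured. It differs from compound 3 by bromo in place of methoxy on an aromatic carbon, the same kind of change as from compound 1 to compound 2, though where that earlier pair differs ortho to a large group, this pair differs para to a large group. Since the earlier step that the two limits leave unreadable from compound 1 to compound 2 is unreadable and every value here sits at or near the limit, compound 4 is expected to stay in the same region, with a 1.1-fold higher number from compound 3 to compound 4 (0.05 log units; within the scatter) as the estimated step. The estimated value for compound 4 in this assay is 150000 nM, ranging from 80000 nM to 300000 nM.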

Compound 4, half-maximal inhibitory concentration: > 150000 nM
Compound 4 gave a limit, no number (the forecaster's own chance of this, stated with the estimate: 55%); the middle value lies on the limit itself.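

In this assay compound 4 gives > 150000 nM, which is a limit of the assay and not a number. Bromo in place of methoxy, para to a large group, gives an at least 1.1-fold higher number from compound 3 to compound 4 (0.04 log units; that floor lies within the scatter); this is only a floor, so it shows no gain from the change at this place and does not fix the true size of the step. The same change ortho to a large group cannot be read, nor can the steps to compound 4 from compound 1 and compound 2, so there is no second size to set beside this one, and the series does not show whether the change carries from one core to another, since nearly all its values rest on a single limit: the limit of > 150000 nM in this assay, at which 3 of the 4 values shown sit.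

The compounds shown leave open whether an amine or a carboxylic acid in place of methoxy or bromo on the same aromatic ring would give values clearly apart from that limit. Also open, as far as these compounds go, is whether an amide in place of the ester, on the shared core, would give numbers in this assay that could be compared step by step.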